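Swapping the aryl group on the saturated ring carbon of compound 1

A few compounds are considered here, and "the series" means these few. Any claim that something is new, unique, unknown or untested is made for them only; others in the source may bear on it.

Compound 1, `COc1cc(C2=NN(C(C)=O)C(c3ccc(F)cc3)O2)cc(OC)c1OC`, was examined in a functional assay on PC-3 cells (Homo sapiens) for antiproliferative activity, read by MTT assay, tested at 1 uM (a higher number here means a stronger effect of the compound at the concentration tested, a lower number a weaker effect), where compound 1 gives 0%. This is the lowest of the two numbers recorded so far. Among the compounds with values here, the other measured compound, compound 2, `COc1cccc(/C=N/NC(=O)c2cc(OC)c(OC)c(OC)c2)c1OC`, gives 53.2% in this assay, a number well above that of compound 1 and beyond the usual scatter; no single-point step between these two is recorded, so only the two values themselves can be compared.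

Compound 3, `COc1cc(C2=NN(C(C)=O)C(c3cccc(C(F)(F)F)c3)O2)cc(OC)c1OC`, has not yet been measured. Relative to compound 1 it carries 3-(trifluoromethyl)phenyl in place of 4-fluorophenyl on a saturated ring carbon. Both groups are single six-membered aromatic rings of carbon only, without hydrogen-bond donors or acceptors, and they are placed on the same ring carbon of the shared core.

Within the data shown here, with no measured step of this kind to lean on, the account expects the change from compound 1 to compound 3 to be small, an expected step of a number 5 percentage points higher from compound 1 to compound 3 (within the scatter) in this assay, likely not beyond the scatter. In this assay compound 3 is therefore estimated at 5%, with an expected range from 0% to 22%.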

Compound 3, a percentage reported as inhibition, at one concentration (the size of the read-out at that concentration, not a potency): 30.1%
Compound 3: middle estimate off by 25.1 percentage points, on the low side, and the stated range ends below it.
By their numbers in this assay, from the lowest: compound 1; then compound 3; then compound 2.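

Within the data shown here, the aryl group on this saturated ring carbon is the first place where a single change can be read: in this assay, 3-(trifluoromethyl)phenyl in place of 4-fluorophenyl gives a number 30.1 percentage points higher from compound 1 to compound 3 (beyond the scatter). The position is therefore not indifferent to the choice of aryl group, even though both groups are single six-membered aromatic rings of carbon only with no hydrogen-bond donors or acceptors, so those shared counts alone do not settle the read-out here. Nothing measured here says which feature of this change accounts for the step.

The change replaces the substituent on the phenyl ring and alters its place on that ring at once, so these compounds cannot separate the two contributions, and a single step cannot show how far the trend extends. Also open, as far as these compounds go, is how the read-out would respond to a chloro, methoxy, amine or nitrile group on that phenyl ring, or to a cyclohexyl group in place of the aryl group altogether.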